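The compounds below may be only part of what the source reports. "The series", "measured", "known", "first", "only" and "open" are said of these compounds alone.

Compound 3 `O=C(C1CC(F)C1)N1CCc2nc(C#Cc3ccccc3)sc2C1` carries a 3-fluorocyclobutyl group on the carbonyl attached to the ring nitrogen of the shared core. Going by the values given here, in an assay on HEK293 cells for positive allosteric modulation of metabotropic glutamate receptor 5 (Homo sapiens), read by FLIPR, with a stated time of 1 h (a higher number here means that more compound is needed for the effect, a lower number that less compound is needed), compound 3 gives 85 nM, one of only two numbers obtained across the set. Compound 1 `O=C1NCCc2nc(C#Cc3ccccc3)sc21`, the lactam, gives 112 nM in this assay, and the two values lie within the scatter of each other, so neither can be placed ahead of the other. Compound 2 `Fc1cccc(C#Cc2nc3c(s2)CN(C2CCC2)CC3)c1` reports > 10000 nM in this assay, which is a limit of the assay rather than a number (the limit of > 10000 nM in this assay, at which 1 of the 3 values shown sits). Compound 4 `O=C(N1CCC(F)CC1)N1CCc2nc(C#Cc3ccccc3)sc2C1` has not yet been measured in this assay. It differs from compound 3 in one place (4-fluoropiperidin-1-yl in place of 3-fluorocyclobutyl on a carbonyl carbon), so that the carbonyl now joins two nitrogens, one in each ring. Among the compounds with values here, no measured pair in this set isolates such a change, and what compound 2 shows cannot be tied to it. The step of a 1.8-fold higher number from compound 3 to compound 4 (0.25 log units; within the scatter) is expected to be small, toward a somewhat higher number, and may well fall within the scatter. On this basis compound 4 is estimated at 150 nM in this assay, with a plausible range from 40 nM to 600 nM.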

Compound 4, half-maximal effective concentration: 74 nM
Beside the measured number, compound 4's estimate is 2.0-fold (0.31 log units) above it; low and high end bracket the measured number.
By their numbers in this assay, from the lowest: compounds 4, 3 and 1 (each within the scatter of the next). At a limit, above all of these: compound 2.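

In this assay the change from 3-fluorocyclobutyl to 4-fluoropiperidin-1-yl on a carbonyl carbon gives a 1.1-fold lower number from compound 3 to compound 4 (0.06 log units; within the scatter). Going by these compounds alone, this is the first pair in the set that differs in one place, and it shows that this position takes a six-membered non-aromatic ring joined through its nitrogen as well as a four-membered ring of carbon only, with no change that can be read, even though the carbonyl now joins two nitrogens and the group entering is larger by the count of its heavy atoms. Nothing measured in the material shown bears on why the two groups give values within the scatter of each other.

Both groups carry a fluorine on a non-aromatic ring, so the compounds shown leave open what the plain piperidin-1-yl or cyclobutyl group, without the fluorine, would give on the same carbonyl carbon. Also open, on these data alone, is how far this place tolerates other kinds of group, such as morpholin-4-yl, an open diethylamino chain, or a ring bearing an amine or a carboxylic acid.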